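A few compounds are considered here, and "the series" means these few. Any claim that something is new, unique, unknown or untested is made for them only; others in the source may bear on it.

Three measured compounds share one core and differ only in the amine that ends the chain on the aromatic oxygen. Compound 1 `CCNCCCOc1ccc2cc(NC(=O)c3ccc(O)c(CC=C(C)C)c3)c(=O)oc2c1C` gives 980 nM in a functional assay on MCF7 cells (Homo sapiens) for antiproliferative activity; a higher number here means a weaker inhibitor, a lower number a stronger inhibitor. Compound 2 `CCN(C)CCCOc1ccc2cc(NC(=O)c3ccc(O)c(CC=C(C)C)c3)c(=O)oc2c1C` carries methyl in place of hydrogen on an amine nitrogen relative to compound 1; in this assay compound 2 gives 2190 nM, so that a 2.2-fold higher number from compound 1 to compound 2 (0.35 log units; beyond the scatter). Compound 3 `CC(C)=CCc1cc(C(=O)Nc2cc3ccc(OCCCNC(C)(C)C)c(C)c3oc2=O)ccc1O` carries tert-butyl in place of ethyl on an amine nitrogen relative to compound 1, and in this assay compound 3 gives 950 nM; thus a 1.0-fold lower number from compound 1 to compound 3 (0.01 log units; within the scatter), while a 2.3-fold lower number from compound 2 to compound 3 (0.36 log units; beyond the scatter).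

Compound 4 `CC(C)=CCc1cc(C(=O)Nc2cc3ccc(OCCCN(C)C(C)(C)C)c(C)c3oc2=O)ccc1O` has not yet been measured. It differs from compound 3 by methyl in place of hydrogen on an amine nitrogen, the same change that was made from compound 1 to compound 2, and the place reads the same in both pairs: an amine nitrogen whose other neighbours are two saturated chain carbons. Among the measured compounds shown here, with only one earlier instance to go on, the expectation for compound 4 is a step of similar size and direction, a 2.1-fold higher number from compound 3 to compound 4 (0.32 log units; beyond the scatter), because the earlier instance gave a 2.2-fold higher number from compound 1 to compound 2 (0.35 log units; beyond the scatter). The estimate for compound 4 in this assay is therefore 2000 nM, expected to lie between 900 nM and 4500 nM.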

Compound 4, half-maximal inhibitory concentration: 1140 nM
Beside the measured number, compound 4's estimate is 1.8-fold (0.24 log units) above it, within the range that was stated.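

In this assay, methyl in place of hydrogen on the amine nitrogen gave a 1.2-fold higher number from compound 3 to compound 4 (0.08 log units; within the scatter), a step inside the scatter where the earlier one lay just beyond it, yet the two steps cannot be told apart: the same change on two cores in this assay, a 2.2-fold higher number (0.35 log units; beyond the scatter) from compound 1 to compound 2 and a 1.2-fold higher number (0.08 log units; within the scatter) from compound 3 to compound 4, 1.9-fold (0.27 log units) apart, within the scatter of two such steps. Tert-butyl in place of ethyl gave a 1.9-fold lower number from compound 2 to compound 4 (0.28 log units; within the scatter), which also agrees with its earlier counterpart: the same change on two cores in this assay, a 1.0-fold lower number (0.01 log units; within the scatter) from compound 1 to compound 3 and a 1.9-fold lower number (0.28 log units; within the scatter) from compound 2 to compound 4, 1.9-fold (0.27 log units) apart, within the scatter of two such steps. With a 1.2-fold higher number from compound 1 to compound 4 (0.07 log units; within the scatter) also inside the scatter, the four compounds show no sign that either change behaves differently from one amine to the other, but with one pair of steps per change, all of them small, they do not establish that the size of a step carries over.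

From the compounds shown here alone, what a cyclic amine such as piperidine or morpholine would do at the end of the chain remains open. So does the effect of a longer chain from the aromatic oxygen to the amine nitrogen, or of a primary amine there.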